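The source may report more compounds than this note shows. Statements on the series, on what has been measured and on what is new or still open speak of the compounds shown alone.

Two compounds built on one shared core were tested in an assay on cells for displacement of a labelled ligand from adenosine receptor A3 (Homo sapiens), read by scintillation counting, with a stated time of 3 h; on this read-out higher numbers stand for weaker inhibition and lower numbers for stronger inhibition. Compound 1 `CC(C)COc1ccc(-c2cn3c(=O)n(-c4ccccc4)nc3c(N)n2)cc1` has no result there: "not determined" (no result reported). Compound 2 `CCCOc1ccc(-c2cn3c(=O)n(-c4ccccc4)nc3c(N)n2)cc1` reaches only a limit of the assay, > 30000 nM, which is the limit of > 30000 nM in this assay, at which 1 of the 2 values shown sits. Compound 3 `Nc1nc(-c2ccc(O)cc2)cn2c(=O)n(-c3ccccc3)nc12` is the next variation: hydrogen in place of propyl on an oxygen on an aromatic ring. Going by the values given here, because compound 2 sits at > 30000 nM, nothing beyond a limit is known for it, and no measured step points in any direction for this change. The expected step of a number no higher from compound 2 to compound 3 (the limit leaves the size open) is none beyond the scatter. Compound 3 is therefore estimated at 30000 nM, between 5000 nM and 150000 nM, most likely again only a limit.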

Compound 3, inhibition constant: 53 nM
Estimate against measurement, compound 3: 570-fold (2.75 log units) above; the measured number lies below the stated range.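

The group on this oxygen clearly matters: hydrogen in place of propyl gives an at least 560-fold lower number from compound 2 to compound 3 (2.75 log units; beyond the scatter) in this assay. Going by these compounds alone, this is the first measured number, and it shows that the shared core can bind the receptor once the propoxy group gives way to hydroxy. The size of the step is only a floor, because compound 2 carries a limit and not a number: the limit of > 30000 nM in this assay, at which 1 of the 3 values shown sits.

On these data alone, how a methoxy group or an amine in place of the hydroxy would fare stays open. So does the question of whether the hydroxy itself helps or the loss of the propyl chain is enough.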